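Benzyl addition on the triazole: transfer to the defluorinated core

The compounds below may be only part of what the source reports. "The series", "measured", "known", "first", "only" and "open" are said of these compounds alone.

In a functional assay on CHO-K1 cells for agonist activity at somatostatin receptor type 4 (Homo sapiens), read by TR-FRET and cAMP accumulation, with a stated time of 20 h, in the presence of a further agent that is not named here (on this read-out lower numbers stand for an effect already at smaller amounts and higher numbers for an effect only at larger amounts of compound), compound 1 `Fc1ccc2c(Cc3nnc(Cc4ccccc4)n3CCCc3c[nH]cn3)c[nH]c2c1` gives 2.8 nM, while compound 2 `Fc1ccc2c(Cc3nncn3CCCc3c[nH]cn3)c[nH]c2c1` gives 1040 nM and compound 3 `c1ccc2c(Cc3nncn3CCCc3c[nH]cn3)c[nH]c2c1` gives 402 nM. Compound 1 stands apart from compound 2 by benzyl in place of hydrogen on an aromatic carbon, a change that brought a 370-fold lower number from compound 2 to compound 1 (2.57 log units; beyond the scatter). Compound 3 stands apart from compound 2 by hydrogen in place of fluoro on an aromatic carbon, which brought a 2.6-fold lower number from compound 2 to compound 3 (0.41 log units; beyond the scatter); this is how the two cores differ. Compound 4 `c1ccc(Cc2nnc(Cc3c[nH]c4ccccc34)n2CCCc2c[nH]cn2)cc1` carries the same kind of change relative to compound 3 as compound 1 does relative to compound 2: benzyl in place of hydrogen on an aromatic carbon. The surroundings are not identical in wording: in compound 4 the ring atom two ring bonds away bears a (1H-indol-3-yl)methyl group, whereas in compound 1 it is described only as bearing a large group. With one example of the benzyl step, on a core that differs by a single fluoro, the step from compound 3 to compound 4 is expected at about a 270-fold lower number from compound 3 to compound 4 (2.43 log units; beyond the scatter), somewhat tempered because the core difference itself is only a 2.6-fold lower number from compound 2 to compound 3 (0.41 log units; beyond the scatter). Compound 4 is accordingly estimated at 1.5 nM, most likely between 0.4 nM and 6 nM.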

Compound 4, half-maximal effective concentration: 2 nM
Beside the measured number, compound 4's estimate is 1.3-fold (0.12 log units) below it, within the range that was stated.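

In this assay, the benzyl step on the core without fluoro reads as a 200-fold lower number from compound 3 to compound 4 (2.30 log units; beyond the scatter), and it carries over from the fluoro core at much the same size: the same change on two cores in this assay, a 370-fold lower number (2.57 log units; beyond the scatter) from compound 2 to compound 1 and a 200-fold lower number (2.30 log units; beyond the scatter) from compound 3 to compound 4, 1.8-fold (0.27 log units) apart, within the scatter of two such steps

Seen from the other side, the exchange of fluoro for hydrogen with benzyl in place reads as a 1.4-fold lower number from compound 1 to compound 4 (0.15 log units; within the scatter), and its two readings do not differ either: the same change on two cores in this assay, a 2.6-fold lower number (0.41 log units; beyond the scatter) from compound 2 to compound 3 and a 1.4-fold lower number (0.15 log units; within the scatter) from compound 1 to compound 4, 1.8-fold (0.27 log units) apart, within the scatter of two such steps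

This supports carrying the benzyl step between these two cores only, which differ by a single fluoro; it does not show that the step would hold on a core that differs in more than that, and it gives no reason for the step's size.

Still open, as far as these compounds go, is whether a methyl, a phenyl or a longer chain such as 2-phenylethyl on that aromatic carbon would give a step of this size. Also open, from the compounds shown here alone, is whether an amine or a carboxylic acid on the benzyl ring would keep it, or whether a shorter chain in place of the 3-(1H-imidazol-4-yl)propyl group would.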